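Trifluoromethoxy on a Shared Core: Cytotoxicity Expectation

The source may report more compounds than this note shows. Statements on the series, on what has been measured and on what is new or still open speak of the compounds shown alone.

Compound 1 `Cc1ccsc1[C@@H]1C[C@H](O)Cc2ccccc2N1` is the starting point; in an ADME assay on THP-1 cells (Homo sapiens) for cytotoxicity (on this read-out lower numbers stand for higher toxicity in this test and higher numbers for lower toxicity in this test), compound 1 gives 579000 nM. Compound 2 `Cc1ccsc1[C@@H]1C[C@H](O)Cc2cc(OC(F)(F)F)ccc2N1` carries the change (trifluoromethoxy in place of hydrogen on an aromatic carbon), and in this assay compound 2 gives 89700 nM, so that a 6.5-fold lower number from compound 1 to compound 2 (0.81 log units; beyond the scatter). Compound 3 `O[C@@H]1Cc2ccccc2N[C@H](c2ccco2)C1` differs from compound 1 by furan-2-yl in place of 3-methylthiophen-2-yl on a saturated ring carbon; in this assay compound 3 gives 236000 nM, and a 2.5-fold lower number from compound 1 to compound 3 (0.39 log units; beyond the scatter). Compound 4 `O[C@@H]1Cc2cc(OC(F)(F)F)ccc2N[C@H](c2ccco2)C1` is not yet measured; it differs from compound 3 by trifluoromethoxy in place of hydrogen on an aromatic carbon, the same change that compound 2 carries relative to compound 1, set on a core that differs by furan-2-yl in place of 3-methylthiophen-2-yl on a saturated ring carbon. Because a 6.5-fold lower number from compound 1 to compound 2 (0.81 log units; beyond the scatter), a step of a 6.6-fold lower number from compound 3 to compound 4 (0.82 log units; beyond the scatter) is expected for compound 4 in this assay. Compound 4 is therefore estimated at 36000 nM, expected to fall between 15000 nM and 90000 nM.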

Compound 4, half-maximal cytotoxic concentration: 135000 nM
Compound 4: middle estimate off by 3.8-fold (0.57 log units), on the low side; measured number above the stated range.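

On the second core, in this assay, trifluoromethoxy in place of hydrogen on an aromatic carbon gives a 1.7-fold lower number from compound 3 to compound 4 (0.24 log units; within the scatter), so the step seen on the core of compound 1 does not carry over in full: the same change on two cores in this assay, a 6.5-fold lower number (0.81 log units; beyond the scatter) from compound 1 to compound 2 and a 1.7-fold lower number (0.24 log units; within the scatter) from compound 3 to compound 4, 3.7-fold (0.57 log units) apart, beyond the scatter of two such steps. Seen from the other side, furan-2-yl in place of 3-methylthiophen-2-yl gives a 1.5-fold higher number from compound 2 to compound 4 (0.18 log units; within the scatter) with trifluoromethoxy present, which likewise departs from the step without it: the same change on two cores in this assay, a 2.5-fold lower number (0.39 log units; beyond the scatter) from compound 1 to compound 3 and a 1.5-fold higher number (0.18 log units; within the scatter) from compound 2 to compound 4, 3.7-fold (0.57 log units) apart, beyond the scatter of two such steps. This shows that the two changes do not simply add on these four compounds, but it does not show why, and two cores give no rule for any others.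

Going by these compounds, whether a third core would follow either step remains open. So does whether an amine or a carboxylic acid on the same aromatic carbon would depend on the core in the same way.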